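Geometry of the ring double bond and lipophilicity

The source may report more compounds than this note shows. Statements on the series, on what has been measured and on what is new or still open speak of the compounds shown alone.

Compound 1 `O=C1CCCCCCCCCCCCCC/C=C2/CC(CO)(CO1)OC2=O` is a macrocyclic lactone that carries a ring double bond drawn in the Z configuration. Among the measured compounds shown here, in a physicochemical assay for lipophilicity (on this read-out lower numbers stand for lower lipophilicity and higher numbers for higher lipophilicity), compound 1 gives 3.85, the single number recorded for it. For the measured compounds named here, compound 2 `CCCCCCCCCCCCC/C=C1/C[C@@](CO)(COC(C)=O)OC1=O`, an open-chain analogue with an acetylated side arm, gives 5.36; 5.36 (2 entries) in this assay, so compound 1 stands well below it on the values shown; no single-point step connects these two compounds. Compound 3 `O=C1CCCCCCCCCCCCCC/C=C2\CC(CO)(CO1)OC2=O` is the unmeasured counterpart of compound 1, and the difference between them is this: the two compounds have the same atoms and bonds; at least one stereo element is drawn with a configuration in one of them and without one in the other: 1 of 2 stereo elements differ; a double bond is drawn Z in compound 1 and E in compound 3. Going by the values given here, no step between measured compounds speaks to such a change, so the expected shift in this assay from compound 1 to compound 3 is estimated at no change at the digits printed from compound 1 to compound 3 (within the scatter), which lies within the usual scatter. For compound 3 the estimated value in this assay is 3.85, expected to fall between 3.5 and 4.2.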

Compound 3, partition coefficient: 3.85
Compound 3: middle estimate and measured number agree at the digits printed; the range from low to high includes it.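

Among the compounds shown here, compounds 1 and 3 give the first single-place comparison in this set, and the change lies in the ring double bond alone: in this assay there is no change at the digits printed from compound 1 to compound 3 (within the scatter). For the compounds shown here, on these two compounds, then, the drawn geometry of that double bond leaves no visible mark on the read-out, something the earlier pair of compounds, with no step between them, could not show. That reading carries one reservation, which concerns how the pair is drawn rather than the values themselves: the fact that one of compounds 1 and 3 is drawn with a defined configuration and the other without, at the place where they differ

The compounds shown leave open whether the geometry of the double bond would count for as little in the open-chain compound 2. They also leave open how this assay would respond to an amine, a carboxylic acid or a longer chain on the shared core.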